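The compounds below may be only part of what the source reports. "The series", "measured", "known", "first", "only" and "open" are said of these compounds alone.

Working notes on the sulfamoyl carbamate series.

In an assay for inhibition of Polyunsaturated fatty acid lipoxygenase ALOX15 (Oryctolagus cuniculus), read by spectrophotometry (on this read-out lower numbers stand for stronger inhibition and higher numbers for weaker inhibition), compound 1 `CC(C)COC(=O)NS(=O)(=O)Nc1cccc(-c2cc3ccccc3[nH]2)c1` gives 30000 nM. Compound 2 `COc1ccc(-c2cc3ccccc3[nH]2)cc1NS(=O)(=O)NC(=O)OCC(C)C` in this assay gives 1450 nM. Among the measured compounds shown here, the single measured step is a 21-fold lower number from compound 1 to compound 2 (1.32 log units; beyond the scatter), and on the two numbers in hand compound 2 stands lowest, with compound 1 as its only neighbour at the higher number.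

Compound 3 `COc1ccc(-c2cc3cc(F)ccc3[nH]2)cc1NS(=O)(=O)NC(=O)OCC(C)C` is not yet measured. It differs from compound 2 by fluoro in place of hydrogen on an aromatic carbon. For the measured compounds named here, the one measured step, a 21-fold lower number from compound 1 to compound 2 (1.32 log units; beyond the scatter), concerns a methoxy on the other aromatic ring and does not touch the fused ring system, so it offers no direct guidance for a fluoro there. Going by the values given here, no measured step bears on this change. With nothing in the data pointing either way, no shift beyond the scatter of this assay is assumed, and the expectation for compound 3 is a number close to that of compound 2, corresponding to a step of a 1.2-fold lower number from compound 2 to compound 3 (0.08 log units; within the scatter). The estimate for compound 3 in this assay is 1200 nM, expected to fall between 350 nM and 4000 nM, the width of that range reflecting the absence of any comparable measured step.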

Compound 3, half-maximal inhibitory concentration: 420 nM
Beside the measured number, compound 3's estimate is 2.9-fold (0.46 log units) above it, within the range that was stated.
By their numbers in this assay, from the lowest: compound 3; then compound 2; then compound 1.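

In this assay, the six-membered aromatic ring of the fused system proves responsive to a single-atom change: 1H-indol-2-yl to 5-fluoro-1H-indol-2-yl gives a 3.5-fold lower number from compound 2 to compound 3 (0.54 log units; beyond the scatter). Among the compounds shown here, the only earlier step, a 21-fold lower number from compound 1 to compound 2 (1.32 log units; beyond the scatter), involved a methoxy on the other aromatic ring, so this is the first evidence that the fused system also affects the read-out, and both steps lead to a lower number. Nothing available explains the fluoro step or says whether the two changes are related.

The compounds shown do not reveal whether chloro, methyl or nitrile in place of fluoro on this carbon would give a similar step, or whether fluoro on another carbon of the same ring would do so. From the compounds shown here alone, it also remains open whether the fluoro step would carry over to the core of compound 1, which lacks the methoxy, and how a carboxylic acid or a longer chain in place of the carbamate ester would read in this assay.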